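The source may hold more compounds than are shown below. What is called first, only, known or untested is meant among the compounds shown, and "the series" means these compounds.

In a functional assay on the whole organism with Mus musculus as the target (a higher number here means that more compound is needed for the effect, a lower number that less compound is needed), compound 1 (`NC(=O)/C=C/c1cccc(C(F)(F)F)c1`) gives 49.5 mg/kg, while compound 2 (`O=C(/C=C/c1cccc(C(F)(F)F)c1)NCCO`) gives 100 mg/kg. This is the higher of the two numbers, so more of compound 2 is needed for the effect. Compound 3 (`CCC(O)CNC(=O)/C=C/c1cccc(C(F)(F)F)c1`) alters the 2-hydroxyethyl group of compound 2 and makes it 2-hydroxybutyl: ethyl in place of hydrogen on a saturated chain carbon bound to an oxygen on a saturated carbon and a saturated chain carbon. Within the data shown here, only one measured step bears on this, and only indirectly: a 2.0-fold higher number from compound 1 to compound 2 (0.31 log units; beyond the scatter), a modest change that placed 2-hydroxyethyl on the amide-type nitrogen. Among the measured compounds shown here, no measured pair shows what an added ethyl does, so the direction remains uncertain. The expected step in this assay is small and not expected to go beyond the scatter: a 1.3-fold lower number from compound 2 to compound 3 (0.10 log units; within the scatter). For compound 3 the estimated value is 80 mg/kg, with an expected range from 35 mg/kg to 170 mg/kg.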

Compound 3, dose for half-maximal effect: 64.4 mg/kg
Compound 3: middle estimate off by 1.2-fold (0.09 log units), on the high side, and the stated range covers the measured number.
By their numbers in this assay, from the lowest: compounds 1, 3 and 2 (each within the scatter of the next, the first and the last beyond it).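

In this assay, ethyl in place of hydrogen on a saturated chain carbon bound to an oxygen on a saturated carbon gives a step that stays within the usual scatter (a 1.6-fold lower number from compound 2 to compound 3 (0.19 log units; within the scatter)), so no real difference can be read from adding this ethyl. The whole 2-hydroxybutyl group in place of the amide hydrogen also stays within the scatter (a 1.3-fold higher number from compound 1 to compound 3 (0.11 log units; within the scatter)), whereas 2-hydroxyethyl at that nitrogen went beyond it (a 2.0-fold higher number from compound 1 to compound 2 (0.31 log units; beyond the scatter)), so a substituent on this nitrogen need not raise the dose needed. Nothing given here explains these numbers.

From the compounds shown here alone, whether a longer chain, an amine or a carboxylic acid at this same carbon would also leave the dose within the scatter remains open. A single ethyl cannot show how much size this position tolerates.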